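Swapping a piperazine for amino: how will clearance shift?

A few compounds are considered here, and "the series" means these few. Any claim that something is new, unique, unknown or untested is made for them only; others in the source may bear on it.

Compound 1 `Cc1ccc(Cn2c(=O)[nH]c3c(N)nc(C(F)(F)F)cc32)nn1`: < 8 mL.min-1.g-1
Compound 2 `CN1CCN(c2ccc(Cn3c(=O)[nH]c4c(N)nc(C(F)(F)F)cc43)cn2)CC1`: 30 mL.min-1.g-1
Compound 3 `Nc1ccc(Cn2c(=O)[nH]c3c(N)nc(C(F)(F)F)cc32)cn1`: not yet measured

Among the measured compounds shown here, in an in vitro ADME assay on microsomes from liver (Homo sapiens) for metabolic stability (a lower number here means slower removal, a higher number faster removal of the compound), compound 2 holds the only exact number so far, 30 mL.min-1.g-1. Compound 1 reads < 8 mL.min-1.g-1, which is a limit of the assay and not a number. Compound 3 differs from compound 2 in one place: amino in place of 4-methylpiperazin-1-yl on an aromatic carbon. In words, it has amino in place of 4-methylpiperazin-1-yl on an aromatic carbon. For the measured compounds named here, no pair of measured compounds differs in just one place, so this expectation rests on thin ground. It leans on compound 1, which also carries no 4-methylpiperazin-1-yl and sits at < 8 mL.min-1.g-1. The expected change is a 3.3-fold lower number from compound 2 to compound 3 (0.52 log units; beyond the scatter), a drop towards slower removal that would go beyond the usual scatter. For compound 3 the estimated value is 9 mL.min-1.g-1, with an expected range from 5 mL.min-1.g-1 to 20 mL.min-1.g-1.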

Compound 3, intrinsic clearance in microsomes: < 7 mL.min-1.g-1
Compound 3: a limit, no number (the forecaster's own chance of this, stated with the estimate: 50%); at least 1.2-fold (0.10 log units) between middle value and limit.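

In this assay, among the compounds shown here, this is the first step between two compounds that differ in one place, so it gives the change a clear direction: amino in place of 4-methylpiperazin-1-yl, on an aromatic carbon next to the ring nitrogen, gives an at least 4.2-fold lower number from compound 2 to compound 3 (0.63 log units; beyond the scatter). That size is only a minimum, since compound 3 reads a limit of the assay and not a number: the limit of < 7 mL.min-1.g-1 in this assay, at which 1 of the 3 values shown sits. Compound 1 also reads a limit of the assay, so its step to compound 3 cannot be read: the limit of < 8 mL.min-1.g-1 in this assay, at which 1 of the 3 values shown sits.

On these data alone, how far intrinsic clearance really falls for compound 3 remains open. Also open, as far as these compounds go, is whether the gain needs the whole 4-methylpiperazin-1-yl group gone, as dimethylamino or a piperazine ring without its methyl on the same carbon could read anywhere from the level of compound 2 down to that of compound 3.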